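A few compounds are considered here, and "the series" means these few. Any claim that something is new, unique, unknown or untested is made for them only; others in the source may bear on it.

Three compounds share one core and differ only in the aryl group carried on the outer ring. Compound 1 `CC[C@@H](Nc1c(C#N)c(-c2ccc(-c3ccccc3C(F)(F)F)cc2)nc2cnccc12)C(N)=O` gives 3.1 in a physicochemical assay for lipophilicity, read by HPLC, at pH 7.5; a higher number here means a more lipophilic compound, a lower number a more polar compound; compound 2 `CC[C@@H](Nc1c(C#N)c(-c2ccc(-c3cccc(Cl)c3F)cc2)nc2cnccc12)C(N)=O` gives 3.1; compound 3 `CC[C@@H](Nc1c(C#N)c(-c2ccc(-c3cccc(Cl)c3OC)cc2)nc2cnccc12)C(N)=O` gives 3.1. Compound 3 thus stands level with both, since the steps of no change at the digits printed from compound 1 to compound 3 (within the scatter) and no change at the digits printed from compound 2 to compound 3 (within the scatter) stay within the scatter, as does no change at the digits printed from compound 1 to compound 2 (within the scatter).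

Compound 4 `CC[C@@H](Nc1c(C#N)c(-c2ccc(-c3ccccc3C)cc2)nc2cnccc12)C(N)=O` carries a smaller aryl group: 2-methylphenyl in place of 3-chloro-2-methoxyphenyl on an aromatic carbon. Every measured swap of this outer aryl group left the read-out unchanged, so a step that exceeds the scatter is not expected here either; the estimate for the move from compound 3 to compound 4 is a number 0.20 log units lower from compound 3 to compound 4 (within the scatter). Compound 4 is therefore expected to give about 2.9, most likely between 2.5 and 3.3.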

Compound 4, distribution coefficient: 3
Compound 4: the middle estimate sits 0.10 log units below what was measured; measured number inside the range.
By their numbers in this assay, from the lowest: compounds 4, 1, 2 and 3 (each within the scatter of the next).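

Compound 1, compound 2 and compound 3 all carry fluorine or chlorine on the outer aryl group, whereas the smaller 2-methylphenyl carries neither and has no hydrogen-bond acceptor. Even so, this assay gives a number 0.10 log units lower from compound 3 to compound 4 (within the scatter) and a number 0.10 log units lower from compound 2 to compound 4 (within the scatter) and a number 0.10 log units lower from compound 1 to compound 4 (within the scatter) so this position has so far tolerated a plain carbon-only aryl group as well. On these data alone, whether an aryl group carrying an amine or a carboxylic acid would stay level here remains open. Nothing shown gives a measured reason for these small steps.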